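The source may report more compounds than this note shows. Statements on the series, on what has been measured and on what is new or still open speak of the compounds shown alone.

In a functional assay on K562 cells (Homo sapiens) for cytotoxicity, read by MTT assay, with a stated time of 72 h (a higher number here means a weaker inhibitor, a lower number a stronger inhibitor), compound 1 `Cc1ccc(S(=O)(=O)n2cc(COC3=C/C(=N\c4ccccc4)c4ccccc4C3=O)nn2)cc1` gives 12200 nM, compound 2 `CC(=O)c1ccc(/N=C2\C=C(OCc3cn(S(=O)(=O)c4ccc(C)cc4)nn3)C(=O)c3ccccc32)cc1` gives 5520 nM, and compound 3 `Cc1ccc(S(=O)(=O)n2cc(COC3=C/C(=N\c4ccc(F)cc4)c4ccccc4C3=O)nn2)cc1` gives 7700 nM. Compound 2 stands clear of compound 1, with a 2.2-fold lower number from compound 1 to compound 2 (0.34 log units; beyond the scatter), a modest change. Compound 4 `COc1ccc(/N=C2\C=C(OCc3cn(S(=O)(=O)c4ccc(C)cc4)nn3)C(=O)c3ccccc32)cc1` has methoxy in place of acetyl on an aromatic carbon. The closest measured change also removes acetyl, and a 1.4-fold higher number from compound 2 to compound 3 (0.14 log units; within the scatter) stays within the scatter. The swap of hydrogen for fluoro, a 1.6-fold lower number from compound 1 to compound 3 (0.20 log units; within the scatter), is also within it. Changes at this place have so far been small, so no step beyond the scatter is expected in this assay. The estimated step is a 1.4-fold higher number from compound 2 to compound 4 (0.16 log units; within the scatter). For compound 4, the estimated value is 8000 nM, with an expected range from 4000 nM to 16000 nM.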

Compound 4, half-maximal inhibitory concentration: > 20000 nM
Compound 4 gave a limit, no number; the forecaster's own chance of this, stated with the estimate: 3%; at least 2.5-fold (0.39 log units) between middle value and limit.
By their numbers in this assay, from the lowest: compounds 2, 3 and 1 (each within the scatter of the next, the first and the last beyond it). At a limit, above all of these: compound 4.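

In this assay compound 4 gives a limit, not a number: the limit of > 20000 nM in this assay, at which 1 of the 4 values shown sits. This place on the aromatic ring is therefore not as forgiving as the earlier small changes suggested, since methoxy in place of acetyl gives an at least 3.6-fold higher number from compound 2 to compound 4 (0.55 log units; beyond the scatter), and methoxy in place of fluoro gives an at least 2.5-fold higher number from compound 3 to compound 4 (0.41 log units; beyond the scatter). Methoxy in place of hydrogen gives an at least 1.6-fold higher number from compound 1 to compound 4 (0.21 log units; that floor lies within the scatter), which does not yet separate the two groups.

On these data alone, how far the number for compound 4 lies past its limit stays open. So does whether an amine, a carboxylic acid or a longer chain such as ethoxy at this place would track acetyl or methoxy.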